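Adding an Amino Group to Compound 1

The compounds below may be only part of what the source reports. "The series", "measured", "known", "first", "only" and "open" are said of these compounds alone.

Compound 1 `COc1ccc(-c2nc3cc(C(F)(F)F)ccc3[nH]2)cc1` is assessed in an ADME assay on BHK cells (Mesocricetus auratus) for cytotoxicity, read by MTT assay, with a stated time of 96 h; a higher number here means that more compound is tolerated, a lower number that less compound is tolerated. Compound 1 gives > 100000 nM, which is a limit of the assay rather than a number. Compound 2 `Fc1ccc(-c2nc3cc(C(F)(F)F)ccc3[nH]2)cc1` gives 25000 nM in this assay. Among the compounds with values here, the one measured step, an at least 4.0-fold lower number from compound 1 to compound 2 (0.60 log units; beyond the scatter), touches a different part of compound 1 and rests on (the limit of > 100000 nM in this assay, at which 1 of the 2 values shown sits). Compound 3 `COc1ccc(-c2nc3cc(C(F)(F)F)ccc3[nH]2)c(N)c1` differs from compound 1 by amino in place of hydrogen on an aromatic carbon of a six-membered aromatic ring of carbon only, ortho to a large group and meta to a methoxy group. Within the data shown here, no measured step changes this position, so the expectation rests on the standing of compound 1 alone. Compound 3 is therefore estimated at 100000 nM in this assay, with a range from 40000 nM to 250000 nM. This amounts to an expected a number no higher from compound 1 to compound 3 (the limit leaves the size open).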

Compound 3, half-maximal cytotoxic concentration: >= 100000 nM
Compound 3: only a limit was reported (the forecaster's own chance of this, stated with the estimate: 60%); the middle value lies on the limit itself.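

In this assay, compound 1 and compound 3 each give only a limit, not a number, so no step can be read between them. The compounds shown leave open whether amino in place of hydrogen on an aromatic carbon changes the tolerated concentration at all.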